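The compounds below may be only part of what the source reports. "The series", "measured", "known", "first", "only" and "open" are said of these compounds alone.

Measured compounds:
Compound 1, `O=c1ccc(-c2ccccc2)nn1CCCCNC(=S)Nc1ccc(Cl)cc1`: in a functional assay on the whole organism (stomach) with Rattus norvegicus as the target (on this read-out lower numbers stand for an effect already at smaller amounts and higher numbers for an effect only at larger amounts of compound), compound 1 gives only a limit of > 100 mg/kg.
Compound 2, `N#CNC(=N)NCCCCCn1nc(-c2ccccc2)ccc1=O`: in this assay compound 2 gives only a limit of > 100 mg/kg.

Among the compounds with values here, compound 2 therefore stands at no measured number at all; its result is a limit, and the one other value shown for this assay is a limit as well, so that both measured compounds sit together at the limit of > 100 mg/kg in this assay, at which 2 of the 2 values shown sit. Nothing in the two values separates compound 2 from compound 1.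

The unmeasured compound 3, `N/C(S)=N/CCCCn1nc(-c2ccccc2)ccc1=O`, differs from compound 2 in one place: a group of 4 heavy atoms (1 carbon, 2 nitrogen, 1 sulfur; no ring) in place of a group of 7 heavy atoms (3 carbon, 4 nitrogen; no ring), on a saturated chain carbon, four bonds along the chain from an aromatic nitrogen. Both the group that leaves and the group that enters are small, open-chain groups on the same saturated chain carbon, and the rest of the molecule stays as in compound 2.

Because both values shown sit at the limit of > 100 mg/kg in this assay, at which 2 of the 2 values shown sit, no step beyond the usual scatter is expected in this assay, in either direction, and the most likely outcome for compound 3 is again a limit rather than a number. Compound 3 is accordingly estimated at 150 mg/kg, within 50 mg/kg to 500 mg/kg, which would mean an expected step that the limit leaves unreadable from compound 2 to compound 3.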

Compound 3, dose for half-maximal effect: 36.3 mg/kg
The estimate for compound 3 lay 4.1-fold (0.62 log units) above the measured number; the measured number lies below the stated range.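

In this assay, the saturated chain carbon, four bonds along the chain from an aromatic nitrogen, proves to be a place where a change of group can be read, with an at least 2.7-fold lower number from compound 2 to compound 3 (0.44 log units; beyond the scatter). Within the data shown here, the earlier compounds could not show this, as neither of them gave a number, and the new step can be read only as a lower bound because compound 2 gives a limit rather than a number: the limit of > 100 mg/kg in this assay, at which 2 of the 3 values shown sit. With the group of 4 heavy atoms, which holds a sulfur, in place of the group of 7 heavy atoms, compound 3 gives the only number among the values shown, so the read-out is not confined to the limit.

The exchange alters the size of the group, its atoms and its count of hydrogen-bond donors and acceptors all at once, and the compounds shown do not tell which of these differences goes with the step. They also leave open how a simple amine or a carboxylic acid at the same place would read, and whether a longer chain carrying the sulfur-containing group would keep a measurable number.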